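Adding a bromo group to compound 3

The source may report more compounds than this note shows. Statements on the series, on what has been measured and on what is new or still open speak of the compounds shown alone.

In a functional assay on B16-F10 cells (Mus musculus) for antiproliferative activity, read by colorimetric assay and MTT assay, with a stated time of 48 h (a higher number here means a weaker inhibitor, a lower number a stronger inhibitor), compound 3 (`O=C(NS(=O)(=O)c1ccccc1)c1ccccn1`) gives 14200 nM and lies within the scatter of the other two measured compounds. These are compound 1 (`O=C(NS(=O)(=O)c1ccccc1)c1cccnc1`) at 14500 nM and compound 2 (`O=C(NS(=O)(=O)c1ccc(Br)cc1)c1ccncc1`) at 8800 nM on the same read-out.

Compound 4 (`O=C(NS(=O)(=O)c1ccc(Br)cc1)c1ccccn1`) differs from compound 3 by a single change (bromo in place of hydrogen on an aromatic carbon): bromo in place of hydrogen on an aromatic carbon, para to a large group. Among the compounds with values here, no measured step isolates this change. Within the data shown here, the only measured step (a 1.0-fold lower number from compound 1 to compound 3 (0.01 log units; within the scatter)) exchanges pyridin-3-yl for pyridin-2-yl on the carbonyl carbon and stays within the scatter. The closest evidence is compound 2 (8800 nM), which carries a bromo group but has a different group on the carbonyl carbon. The step expected in this assay (a 1.5-fold lower number from compound 3 to compound 4 (0.17 log units; within the scatter)) is therefore small, toward a lower number, and not expected to exceed the scatter. The estimate for compound 4 is 9500 nM (expected range 5500 nM to 15500 nM).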

Compound 4, half-maximal inhibitory concentration: 8500 nM
For compound 4 the middle estimate is 1.1-fold (0.05 log units) above the measured one, within the range that was stated.
By their numbers in this assay, from the lowest: compounds 4, 2, 3 and 1 (each within the scatter of the next).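

In this assay the change from hydrogen to bromo, para to a large group, now has a measured step of its own (a 1.7-fold lower number from compound 3 to compound 4 (0.22 log units; within the scatter)), and with pyridin-2-yl on the carbonyl carbon this change stays inside the scatter. Within the data shown here, the bromo compounds also give the first reading of the group on the carbonyl carbon with this bromo group present (a 1.0-fold lower number from compound 2 to compound 4 (0.02 log units; within the scatter)), and that exchange likewise stays inside the scatter, as the earlier step without the bromo group did. Nothing available bears on why these steps are so small.

The compounds shown leave open whether an amine, a methoxy group or a carboxylic acid at this place would move the number beyond the scatter. They also leave open how the bromo group behaves with pyridin-3-yl on the carbonyl carbon.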